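This account rests on a few compounds, and the source may have more. Where it says the series, first, only, none or still open, it means among the compounds named here.

Measured so far in a functional assay for inhibition of sodium/hydrogen exchanger (Oryctolagus cuniculus); on this read-out higher numbers stand for weaker inhibition and lower numbers for stronger inhibition:
compound 1 `Cc1c(C(=O)N=C(N)N)cc(S(C)(=O)=O)c(Cl)c1C`: 58 nM
compound 2 `Cc1c(C(=O)N=C(N)N)cc(S(C)(=O)=O)c(Cl)c1[N+](=O)[O-]`: 44 nM
compound 3 `Cc1cc(-c2ccco2)c(S(C)(=O)=O)cc1C(=O)N=C(N)N`: 16 nM

Compound 3 gives the lowest number of the three in this assay; compound 2 lies nearest to it and compound 1 furthest, both gaps beyond the scatter. Going by the values given here, the one single-point step in the set, a 1.3-fold lower number from compound 1 to compound 2 (0.12 log units; within the scatter), concerns a nitro in place of a methyl and lies within the scatter; it does not touch the position changed here.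

Compound 4 `Cc1cc(Oc2ccc(Cl)cc2)c(S(C)(=O)=O)cc1C(=O)N=C(N)N` differs from compound 3 by 4-chlorophenoxy in place of furan-2-yl on an aromatic carbon. Among the compounds with values here, no measured pair shows an aryl ether in place of a five-membered aromatic ring at this place, so the direction of the step cannot be taken from the data. With the substituent kept at the same place, the number is expected to stay near that of compound 3, with room for a moderate move either way. The expected step is a 1.3-fold higher number from compound 3 to compound 4 (0.10 log units; within the scatter). Compound 4 is thus estimated at 20 nM, with a range of 6 nM to 65 nM.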

Compound 4, half-maximal inhibitory concentration: 13 nM
Estimate against measurement, compound 4: 1.5-fold (0.19 log units) above, within the range that was stated.
By their numbers in this assay, from the lowest: compounds 4 and 3 (each within the scatter of the next); then compounds 2 and 1 (each within the scatter of the next).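

Changing the group on the aromatic carbon ortho to a methylsulfonyl group gives a 1.2-fold lower number from compound 3 to compound 4 (0.09 log units; within the scatter) in this assay, so this step does not separate the two groups. At this place, furan-2-yl with 5 heavy atoms and 4-chlorophenoxy with 8 heavy atoms read alike, even though a five-membered aromatic ring with 1 hetero atom gives way to a six-membered aromatic ring of carbon only, carried by an ether oxygen. No measurement at hand explains this agreement or tells how either group acts at this place.

As far as these compounds go, the contribution of the chlorine remains open, and plain phenoxy at this carbon would address it. An amine such as piperidin-1-yl or a carboxylic acid at the same place would show whether the read-out stays level with groups of a different kind.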